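Methyl to fluoro: from compound 2 to compound 4

The compounds below may be only part of what the source reports. "The series", "measured", "known", "first", "only" and "open" are said of these compounds alone.

- compound 1 `C[C@@H](Oc1cc2ccn(CCC(=O)O)c2cc1Cl)c1ccccn1`: 2.17
- compound 2 `Cc1ccc([C@@H](C)Oc2cc3onc(CCC(=O)O)c3cc2Cl)nc1`: 2.42
- compound 3 `O=C(O)CCn1c(=O)oc2cc(OCc3ccccn3)c(Cl)cc21`: 1.32

In a physicochemical assay for lipophilicity, read by HPLC, at pH 7.4 (on this read-out higher numbers stand for higher lipophilicity and lower numbers for lower lipophilicity), compound 2 at 2.42 stands within the scatter of compound 1 at 2.17, while compound 3 at 1.32 lies lower, beyond the scatter. Compound 4 `C[C@@H](Oc1cc2onc(CCC(=O)O)c2cc1Cl)c1ccc(F)cn1` has not yet been measured. It differs from compound 2 in one place: fluoro in place of methyl on an aromatic carbon. This is fluoro in place of methyl on an aromatic carbon, turning 5-methylpyridin-2-yl into 5-fluoropyridin-2-yl. Among the measured compounds shown here, no measured pair here shows this change, so the expectation rests on the change alone. A modest fall of about the size of the scatter is expected in this assay, with the estimated change being a number 0.30 log units lower from compound 2 to compound 4 (within the scatter). For compound 4 the estimated value is 2.12, with an expected range from 1.8 to 2.45.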

Compound 4, distribution coefficient: 2.47
Estimate against measurement, compound 4: 0.35 log units below, and the stated range ends below it.
By their numbers in this assay, from the lowest: compound 3; then compounds 1, 2 and 4 (each within the scatter of the next).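

In this assay, fluoro in place of methyl on this aromatic carbon, two atoms from the ring nitrogen, gives a number 0.05 log units higher from compound 2 to compound 4 (within the scatter). Among the compounds shown here, this is the first direct reading of the change here, since none of the earlier compounds formed a pair differing in one place, and on the shared core the swap stays inside the scatter. No measured evidence bears on why the step is this size.

As far as these compounds go, it remains open whether the swap reads the same on the core of compound 1. From the compounds shown here alone, it also remains open whether trifluoromethyl or an amine at this position would give a step beyond the scatter.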